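The source may hold more compounds than are shown below. What is called first, only, known or untested is meant among the compounds shown, and "the series" means these compounds.

Three compounds built on one shared core were tested in an ADME assay on THP-1 cells (Homo sapiens) for cytotoxicity, read by MTT assay, with a stated time of 72 h; on this read-out higher numbers stand for an effect only at larger amounts of compound and lower numbers for an effect already at smaller amounts. Compound 1 `O=c1nc(-c2ccccc2)c2cc(-c3ccc(F)cc3)ccc2[nH]1` gives > 50000 nM in this assay, which is a limit rather than a number. Compound 2 `O=c1nc(-c2ccccc2)c2cc(-c3cncnc3)ccc2[nH]1` likewise returns only a limit, > 50000 nM. Compound 3 `O=c1nc(-c2ccccc2)c2ccc(-c3cncnc3)cc2[nH]1` also stops at a limit, > 50000 nM. The change from compound 2 to compound 1 is 4-fluorophenyl in place of pyrimidin-5-yl on an aromatic carbon, and the step that the two limits leave unreadable from compound 2 to compound 1 cannot be sized because of the limit of > 50000 nM in this assay, at which 3 of the 3 values shown sit. The difference between the cores of compound 2 and compound 3 is not broken down here. Compound 4 `O=c1nc(-c2ccccc2)c2ccc(-c3ccc(F)cc3)cc2[nH]1` remains to be measured; it differs from compound 3 by 4-fluorophenyl in place of pyrimidin-5-yl on an aromatic carbon, the same change as from compound 2 to compound 1. Because (the limit of > 50000 nM in this assay, at which 3 of the 3 values shown sit), compound 4 is expected to give 50000 nM in this assay, an estimated step of a number no higher from compound 3 to compound 4 (the limit leaves the size open).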

Compound 4, half-maximal effective concentration: > 50000 nM
Compound 4: no number, only a limit (the forecaster's own chance of this, stated with the estimate: 90%); the middle value sits exactly at the limit.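

Compound 3 and compound 4 both stop at a limit in this assay, so no step can be read between them: the limit of > 50000 nM in this assay, at which 4 of the 4 values shown sit.

The compounds shown leave open whether 4-fluorophenyl, pyrimidin-5-yl or their place on the shared core changes the result in this assay at all.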